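This account rests on a few compounds, and the source may have more. Where it says the series, first, only, none or still open, it means among the compounds named here.

Measured so far in an assay on isolated protein for inhibition of NUAK family SNF1-like kinase 1 (Homo sapiens), read by ADP-Glo, with a stated time of 60 min, tested at 10 uM, in the presence of a further agent that is not named here; a lower number here means less inhibition, a higher number more inhibition at the concentration tested (going by the name of the read-out):
- compound 1 `CCC(=O)Nc1cccc(Oc2nc(Nc3ccc(N4CCN(C)CC4)cc3)ncc2Cl)c1`: 92.9%
- compound 2 `CCC(=O)Nc1cccc(Oc2nc(Nc3ccc(N4CCCC4)cc3OC)ncc2Cl)c1`: 25.8%
- compound 3 `CCCN(CCC)c1ccc(Nc2ncc(Cl)c(Oc3cccc(NC(=O)CC)c3)n2)c(OC)c1`: "not active" (no number reported), with no number given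

Compound 1 gives the highest of the two numbers in this assay, and compound 2 stands well below it, a gap beyond the scatter. Compound 3 is reported as not active without a number. Compounds 2 and 3 each differ from compound 1 in more than one place, so no single change among the measured compounds can be read off as a step.

The next compound, compound 4 `CCC(=O)Nc1cccc(Oc2nc(Nc3ccc(N(C)C)cc3)ncc2Cl)c1`, keeps the shared core of compound 1 and differs only at one point: dimethylamino in place of 4-methylpiperazin-1-yl on an aromatic carbon. The amine on that aromatic ring is kept, only smaller. Going by the values given here, since the measured compounds give no isolated step for a change of this kind, the expectation rests on the high number of compound 1 alone. The step from compound 1 to compound 4 is expected to be a modest loss, a number 17.9 percentage points lower from compound 1 to compound 4 (beyond the scatter), possibly within the scatter. Compound 4 is therefore expected to give about 75%, with a range from 45% to 95%.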

Compound 4, a percentage reported as inhibition, at one concentration (the size of the read-out at that concentration, not a potency): 72.6%
Compound 4: the middle estimate sits 2.4 percentage points above what was measured, and the stated range covers the measured number.
By their numbers in this assay, from the lowest: compound 2; then compound 4; then compound 1.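

In this assay, this position now has its first single-place reading: dimethylamino in place of 4-methylpiperazin-1-yl gives a number 20.3 percentage points lower from compound 1 to compound 4 (beyond the scatter). The change is therefore not neutral, yet a small open-chain amine on this aromatic carbon keeps much of the inhibition, with compound 4 at 72.6% at the single concentration tested. No measurement here bears on why the number falls.

Still open, on these data alone, is which part of the departing group matters: the ring itself, its size or its second nitrogen. A piperidin-1-yl group, a morpholin-4-yl group or a diethylamino group at the same place, each on the core of compound 1, would begin to separate these possibilities.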